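The source may report more compounds than this note shows. Statements on the series, on what has been measured and on what is new or still open speak of the compounds shown alone.

Measured so far in a functional assay on PC-3 cells (Homo sapiens) for antiproliferative activity, read by MTT assay, with a stated time of 48 h; on this read-out higher numbers stand for weaker inhibition and lower numbers for stronger inhibition:
Compound 1 `Cc1cccn2cc(-c3nnc(-c4ccc(Br)cc4)o3)nc12`: 37800 nM
Compound 2 `COc1ccc(-c2nnc(-c3cn4cccc(C)c4n3)o2)cc1`: 11800 nM

Compound 2 has the lower of the two numbers. Compound 3 `Cc1cccn2cc(-c3nnc(-c4ccc(N(C)C)cc4)o3)nc12` has dimethylamino in place of methoxy on an aromatic carbon, para to a large group (dimethylamino in place of methoxy on an aromatic carbon). Among the measured compounds shown here, only one measured step bears on this change, a modest one with methoxy in place of bromo on an aromatic carbon: a 3.2-fold lower number from compound 1 to compound 2 (0.51 log units; beyond the scatter). With so little evidence, no step beyond the scatter is expected in this assay. The expected result is a 1.2-fold lower number from compound 2 to compound 3 (0.07 log units; within the scatter). For compound 3 the estimated value is 10000 nM, with an expected range of 3500 nM to 30000 nM.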

Compound 3, half-maximal inhibitory concentration: 11600 nM
Compound 3: middle estimate off by 1.2-fold (0.06 log units), on the low side, and the stated range covers the measured number.
By their numbers in this assay, from the lowest: compounds 3 and 2 (each within the scatter of the next); then compound 1.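

In the antiproliferative read-out (this assay), dimethylamino in place of methoxy on the aromatic carbon para to a large group gives no step beyond the scatter (a 1.0-fold lower number from compound 2 to compound 3 (0.01 log units; within the scatter)), so the two groups cannot be told apart here. Dimethylamino in place of bromo gives a step beyond the scatter (a 3.3-fold lower number from compound 1 to compound 3 (0.51 log units; beyond the scatter)), leaving compound 1 with the highest number of the three. No measured evidence explains this result.

The compounds shown leave open how a carboxylic acid, a primary amine or a longer alkoxy chain would read at this position. They also leave open whether methoxy and dimethylamino would stay level at another position on this ring.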